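Cytotoxicity notes: one side-chain swap on two cores

A few compounds are considered here, and "the series" means these few. Any claim that something is new, unique, unknown or untested is made for them only; others in the source may bear on it.

Compound 1 `CN1CCN(CC#Cc2cc3c(Nc4ccc(OCc5cccc(F)c5)c(Cl)c4)ncnc3s2)CC1` and compound 3 `CN1CCN(CC#Cc2ccc3ncnc(Nc4ccc(OCc5cccc(F)c5)c(Cl)c4)c3c2)CC1` carry the same 3-(4-methylpiperazin-1-yl)prop-1-yn-1-yl group on different cores; the difference between the two cores is not broken down here. In an ADME assay on NIH3T3 cells (Mus musculus) for cytotoxicity (a lower number here means that less compound is tolerated, a higher number that more compound is tolerated), compound 1 gives 6.7 uM. In this assay compound 3 gives 7.2 uM, which sits within the scatter of compound 1. Compound 2 `CCOC(=O)CN(C)CC#Cc1cc2c(Nc3ccc(OCc4cccc(F)c4)c(Cl)c3)ncnc2s1` differs from compound 1 by ((ethoxycarbonyl)methyl)(methyl)amino in place of 4-methylpiperazin-1-yl on a saturated chain carbon bound to a triple-bonded carbon. For compound 2 the reading in this assay is a limit of the assay, > 50 uM, namely (the limit of > 50 uM in this assay, at which 1 of the 3 values shown sits). The step is an at least 7.4-fold higher number from compound 1 to compound 2 (0.87 log units; beyond the scatter). Compound 4 `CCOC(=O)CN(C)CC#Cc1ccc2ncnc(Nc3ccc(OCc4cccc(F)c4)c(Cl)c3)c2c1`, not yet measured, differs from compound 3 by ((ethoxycarbonyl)methyl)(methyl)amino in place of 4-methylpiperazin-1-yl on a saturated chain carbon bound to a triple-bonded carbon, the same change at the same place. Since compound 3 gives 7.2 uM, the step from compound 3 to compound 4 is expected to be a 7.6-fold higher number from compound 3 to compound 4 (0.88 log units; beyond the scatter), resting on the step of an at least 7.4-fold higher number from compound 1 to compound 2 (0.87 log units; beyond the scatter) seen on the other core. Compound 4 is therefore estimated at 55 uM in this assay, quite possibly reported again only as a limit.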

Compound 4, half-maximal toxic concentration: > 50 uM
Compound 4 ended at the assay's limit; the forecaster's own chance of this, stated with the estimate: 65%; the middle value lies beyond the limit too.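

In this assay, ((ethoxycarbonyl)methyl)(methyl)amino in place of 4-methylpiperazin-1-yl gives an at least 6.9-fold higher number from compound 3 to compound 4 (0.84 log units; beyond the scatter), so on the core of compound 3 the change runs in the same direction as on the core of compound 1 and again lies beyond the scatter. Set beside the step on the core of compound 1, the comparison reads: the same change on two cores in this assay, an at least 7.4-fold higher number (0.87 log units; beyond the scatter) from compound 1 to compound 2 and an at least 6.9-fold higher number (0.84 log units; beyond the scatter) from compound 3 to compound 4; the limit leaves it open whether they differ On these two cores the change carries over in direction, but neither its full size on either core nor any carry-over to a further core is shown, and both products sit at the same limit: the limit of > 50 uM in this assay, at which 2 of the 4 values shown sit.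

The compounds shown leave open whether the higher number goes with the ethoxycarbonyl part or with the loss of the piperazine ring, since the two groups differ in both. A plain open-chain amine such as dimethylamino, or a carboxylic acid in place of the ethoxycarbonyl part, would separate these two readings on either core.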